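This account rests on a few compounds, and the source may have more. Where it says the series, first, only, none or still open, it means among the compounds named here.

Measured compounds:
- compound 1, `CCc1ccc(NC(=O)Nc2cc(C)nc3ccccc23)cc1`: 17000 nM
- compound 2, `Cc1cc(NC(=O)Nc2ccccc2N)c2ccccc2n1`: > 25000 nM, which is a limit of the assay and not a number.

Both were tested in an ADME assay on HepG2 cells (Homo sapiens) for cytotoxicity, with a stated time of 72 h; on this read-out lower numbers stand for an effect already at smaller amounts and higher numbers for an effect only at larger amounts of compound. For the measured compounds named here, compound 1 gives the only actual number on this read-out, 17000 nM. Compound 2 sits at a limit, (the limit of > 25000 nM in this assay, at which 1 of the 2 values shown sits), so it offers no number to set beside compound 1. Going by the values given here, with no pair of measured compounds differing in one place, no measured step is available to guide the next change.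

The unmeasured compound 3, `COc1ccc(NC(=O)Nc2cc(C)nc3ccccc23)cc1`, shares the core of compound 1 and differs from it in a single spot: methoxy in place of ethyl on an aromatic carbon. The ethyl and the methoxy are of the same size by heavy-atom count, and the methoxy brings one hydrogen-bond acceptor where the ethyl had none.

With nothing measured on this kind of change, the step from compound 1 to compound 3 is expected to stay within the usual scatter, a 1.2-fold higher number from compound 1 to compound 3 (0.07 log units; within the scatter), and no direction is favoured. Compound 3 is therefore estimated at 20000 nM, with a range from 9000 nM to 45000 nM.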

Compound 3, half-maximal effective concentration: > 25000 nM
Compound 3 was reported as a limit; the forecaster's own chance of this, stated with the estimate: 35%; at least 1.2-fold (0.09 log units) between middle value and limit.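

For the compounds shown here, compound 3 gives the first measured step at this spot, on an aromatic carbon para to a large group: exchanging ethyl for methoxy in this assay gives an at least 1.4-fold higher number from compound 1 to compound 3 (0.16 log units; that floor lies within the scatter). Since the value of compound 3, > 25000 nM, is a limit of the assay and not a number, this step is only a floor, and the real difference could be small or much larger. The new information is therefore one-sided: adding a hydrogen-bond acceptor at this position without changing the heavy-atom count did not give a lower number than ethyl, and the result joins the other value that cannot be read as a number:
the limit of > 25000 nM in this assay, at which 2 of the 3 values shown sit.

On these data alone, how far the true value of compound 3 lies from that of compound 1 remains open, so the size of this change cannot yet be stated. Also open, as far as these compounds go, is whether an amine, a hydroxyl group or a longer chain such as propyl at this same position would give a readable number on this read-out, and on which side of compound 1 it would fall.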